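A few compounds are considered here, and "the series" means these few. Any claim that something is new, unique, unknown or untested is made for them only; others in the source may bear on it.

Working notes on the quinoline-styrene series. Compound 1 `FC(F)(F)c1ccc(/C=C\c2cc3ccc(Cl)cc3nc2Cl)cc1`, compound 2 `Fc1ccc(/C=C\c2cc3ccc(Cl)cc3nc2Cl)cc1` and compound 3 `COc1ccc2nc(Cl)c(/C=C\c3ccc(C(F)(F)F)cc3)cc2c1` have been run in a functional assay on MDA-MB-231 cells (Homo sapiens) for antiproliferative activity, read by sulforhodamine B assay, with a stated time of 72 h; a higher number here means a weaker inhibitor, a lower number a stronger inhibitor. In this assay compound 1 gives 13600 nM, compound 2 gives 42600 nM and compound 3 gives 22800 nM. Among the measured compounds shown here, the one single-point change measured so far is fluoro in place of trifluoromethyl on an aromatic carbon, which produced a 3.1-fold higher number from compound 1 to compound 2 (0.50 log units; beyond the scatter). Compound 3 and compound 1 share the same trifluoromethyl-bearing styrene but carry different cores; the difference between the two cores is not broken down here, and their values in this assay lie within the scatter of each other.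

Compound 4 `COc1ccc2nc(Cl)c(/C=C\c3ccc(F)cc3)cc2c1` is not yet measured. For the measured compounds named here, it differs from compound 3 by fluoro in place of trifluoromethyl on an aromatic carbon, the same change, at the same place, as the one from compound 1 to compound 2. Going by the values given here, since the only precedent is a single occurrence, the expectation rests on it alone: the measured precedent is a 3.1-fold higher number from compound 1 to compound 2 (0.50 log units; beyond the scatter). The step from compound 3 to compound 4 is expected to resemble that precedent, giving a 2.6-fold higher number from compound 3 to compound 4 (0.42 log units; beyond the scatter). On that basis compound 4 is estimated at 60000 nM in this assay, with a plausible range from 25000 nM to 150000 nM.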

Compound 4, half-maximal inhibitory concentration: 11400 nM
Compound 4: middle estimate off by 5.3-fold (0.72 log units), on the high side; measured number outside the range, below it.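

In this assay, fluoro in place of trifluoromethyl gives a 2.0-fold lower number from compound 3 to compound 4 (0.30 log units; within the scatter), so the rise in the number seen on the core of compound 1 is not repeated on the core of compound 3. The outcome of this change therefore depends on the core in these two pairs, and a step measured on one core cannot simply be transferred to the other: the same change on two cores in this assay, a 3.1-fold higher number (0.50 log units; beyond the scatter) from compound 1 to compound 2 and a 2.0-fold lower number (0.30 log units; within the scatter) from compound 3 to compound 4, 6.3-fold (0.80 log units) apart, beyond the scatter of two such steps. This does not show which feature of the two cores sets the steps apart, and with one pair per core it gives no general rule for the series.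

The compounds shown leave open how a group other than these two, such as an amine or a carboxylic acid, would behave at this place on either core. They also leave open whether a further core would follow the step seen with compound 1 and compound 2, the step seen with compound 3 and compound 4, or neither.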